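The source may report more compounds than this note shows. Statements on the series, on what has been measured and on what is new or still open speak of the compounds shown alone.

Measured so far in a functional assay on Hs-578T cells (Homo sapiens) for inhibition, read by sulforhodamine B assay, with a stated time of 48 h; on this read-out higher numbers stand for weaker inhibition of growth and lower numbers for stronger inhibition of growth:

compound 1 `Nc1cc(N)c2nc(-c3ccccc3)c(Oc3ccc(Cl)c(Cl)c3)nc2c1` — 33900 nM
compound 2 `Nc1cc(N)c2nc(-c3ccccc3)c(NCc3ccc(Cl)c(Cl)c3)nc2c1` — 46800 nM
compound 3 `CCOC(=O)[C@H](CCC(=O)O)NC(=O)c1ccc(Sc2nc3cc(N)cc(N)c3nc2-c2ccccc2)cc1` — 75900 nM

Compound 1 gives the lowest of the three numbers. Compound 2 lies nearest, and its number sits within the usual scatter of that of compound 1, so no order between the two can be read. Compound 3 lies furthest, with a higher number that falls beyond the scatter. Within the data shown here, no pair of measured compounds differs in only one place, so no single step has been measured.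

Compound 4 `Nc1cc(N)c2nc(-c3ccccc3)c(Sc3ccc(F)cc3)nc2c1` is not yet measured. It differs from compound 1 in one place: (4-fluorophenyl)sulfanyl in place of 3,4-dichlorophenoxy on an aromatic carbon

Compound 3, which also carries a sulfur-linked group on the shared core, gives 75900 nM, the highest number in the set, but its substituent is much larger than that of compound 4. The step from compound 1 to compound 4 in this assay is expected to be small, toward a somewhat higher number, and not clearly beyond the scatter; the estimated step is a 1.2-fold higher number from compound 1 to compound 4 (0.07 log units; within the scatter). Compound 4 is expected to give 40000 nM, with a range from 15000 nM to 110000 nM.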

Compound 4, concentration for total growth inhibition: 61700 nM
The estimate for compound 4 lay 1.5-fold (0.19 log units) below the measured number; the measured number falls inside the stated range.
By their numbers in this assay, from the lowest: compounds 1, 2, 4 and 3 (each within the scatter of the next, the first and the last beyond it).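

In this assay, among these compounds, the first single-place step at this position reads a 1.8-fold higher number from compound 1 to compound 4 (0.26 log units; within the scatter) and so gives no readable difference. Linking atom and ring halogens change together here, from an oxygen-linked 3,4-dichlorophenyl to a sulfur-linked 4-fluorophenyl, and this double exchange on the aromatic carbon leaves the number within the scatter. Nothing measured on these compounds accounts for the size of this step.

Among the compounds shown here, the single step cannot separate the linking atom from the halogen pattern, and 4-fluorophenoxy or (3,4-dichlorophenyl)sulfanyl at this position would divide the exchange into its two parts. On these data alone, whether an unsubstituted phenoxy, a morpholine or a short alkylamine on the same carbon would stay within the scatter of compound 1 remains open.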